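A few compounds are considered here, and "the series" means these few. Any claim that something is new, unique, unknown or untested is made for them only; others in the source may bear on it.

The shared core is shown for compound 1 as `Fc1ccc(Oc2ccnc3ccsc23)cc1`. In an ADME assay on PLP2 cells (Sus scrofa) for inhibition, read by sulforhodamine B assay, with a stated time of 48 h (on this read-out higher numbers stand for weaker inhibition of growth and lower numbers for stronger inhibition of growth), compound 1 gives > 125000 nM, which is a limit of the assay and not a number. Compound 1 thus stands at the limit of > 125000 nM in this assay, at which 2 of the 3 values shown sit, so its place among the values shown cannot be ranked more finely. Two further compounds carry a methoxy in place of the fluoro. Compound 2, `COc1cccc(Oc2ccnc3ccsc23)c1`, gives 26700 nM in this assay. Compound 3, `COc1ccccc1Oc1ccnc2ccsc12`, gives > 125000 nM in this assay, again a limit of the assay rather than a number. The unmeasured compound 4, `COc1ccc(Oc2ccnc3ccsc23)cc1`, differs from compound 1 by methoxy in place of fluoro on an aromatic carbon, a methoxy in place of fluoro on an aromatic carbon, para to a large group. Within the data shown here, no step between measured compounds is available, so the outlook for compound 4 rests on the three values alone. Since compound 1 gives only a limit, the size of the step it opens cannot be fixed. A move toward stronger inhibition of growth in this assay is possible, as compound 2 with 26700 nM hints. Compound 3, however, stays at the limit. Compound 4 is expected to give 70000 nM, within 20000 nM to 250000 nM. The step from compound 1 to compound 4 is estimated at an at least 1.7-fold lower number from compound 1 to compound 4 (0.25 log units; that floor lies within the scatter) in this assay, with a fair chance that only a limit is reported.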

Compound 4, concentration for 50% growth inhibition: 94500 nM
Compound 4: the middle estimate sits 1.4-fold (0.13 log units) below what was measured, within the range that was stated.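

With the methoxy on this aromatic carbon, para to a large group, compound 4 gives 94500 nM in this assay, a measured number at a place where compound 1, with fluoro, does not give one. The entry for compound 1, > 125000 nM, is a limit of the assay and not a number. The change can therefore be read only as an at least 1.3-fold lower number from compound 1 to compound 4 (0.12 log units; that floor lies within the scatter), so this result does not establish a real difference between fluoro and methoxy here, and the full size of the step stays unknown, with the limit still shared among the values shown: the limit of > 125000 nM in this assay, at which 2 of the 4 values shown sit.

The compounds shown leave open whether another group at this same place, such as an amine, a carboxylic acid or a longer chain like ethoxy, would give a clearly lower number in this assay. They also leave open how far the pattern holds for the methoxy elsewhere on the ring, since compound 2 gives 26700 nM and compound 4 gives 94500 nM, and two such values offer no basis for a general rule on position.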